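This account rests on a few compounds, and the source may have more. Where it says the series, first, only, none or still open, it means among the compounds named here.

Compound 1 `C/C(=C\c1ccc(-c2ccc(C)cc2)o1)C(N)=O`: in a functional assay on BGC-823 cells (Homo sapiens) for cytotoxicity, read by CCK-8 assay, with a stated time of 24 h (on this read-out higher numbers stand for weaker inhibition and lower numbers for stronger inhibition), compound 1 gives > 50000 nM, a limit of the assay.
Compound 2 `C/C(=C\c1cc(-c2ccccc2)cs1)C(N)=O`: in this assay compound 2 gives > 50000 nM, also a limit.
Compound 3 `C/C(=C\c1cc(-c2ccccc2C)cs1)C(N)=O`: in this assay compound 3 gives > 50000 nM, again a limit.

Compound 2 therefore stands only at a limit, as do the other two measured compounds, so none of them can be ranked against another. Compound 4 `C/C(=C\c1cc(-c2ccc(C(F)(F)F)cc2)cs1)C(N)=O` differs from compound 2 by trifluoromethyl in place of hydrogen on an aromatic carbon. Among the measured compounds shown here, the one measured step that resembles this change, a step that the two limits leave unreadable from compound 2 to compound 3, cannot be read, since (the limit of > 50000 nM in this assay, at which 3 of the 3 values shown sit). Nothing measured here points to a gain or loss beyond the scatter in this assay, and the step from compound 2 to compound 4 is expected to be a step that the limit leaves unreadable from compound 2 to compound 4. Compound 4 is estimated to give 80000 nM in this assay, most likely again as a limit, within a range from 20000 nM to 300000 nM.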

Compound 4, half-maximal inhibitory concentration: > 50000 nM
Compound 4: only a limit was reported; the forecaster's own chance of this, stated with the estimate: 80%; the middle value lies beyond the limit too.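

No step can be read from compound 2 to compound 4, since both sit at a limit, as does compound 3: the limit of > 50000 nM in this assay, at which 4 of the 4 values shown sit.

The compounds shown leave open which structural change, if any, would give a measurable value in this assay.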